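The source may report more compounds than this note shows. Statements on the series, on what has been measured and on what is new or still open speak of the compounds shown alone.

Among the compounds with values here, compound 2 `O=c1[nH]cc(S(=O)(=O)Nc2ccccc2-c2cn(-c3ccccc3Cl)nn2)c(=O)[nH]1` is the only compound with a number in an ADME assay on GES1 cells (Homo sapiens) for cytotoxicity, read by MTT assay, with a stated time of 24 h (a lower number here means that less compound is tolerated, a higher number that more compound is tolerated), where compound 2 gives 20800 nM. Compound 1 `O=c1[nH]cc(S(=O)(=O)Nc2ccccc2-c2cn(-c3ccc(F)cc3)nn2)c(=O)[nH]1` is described only as "not toxic" (no number reported) there, with no number reported, so it offers no scale for comparison. Compound 3 `O=c1[nH]cc(S(=O)(=O)Nc2ccccc2-c2cn(-c3ccc(Cl)cc3)nn2)c(=O)[nH]1` differs from compound 2 by 4-chlorophenyl in place of 2-chlorophenyl on an aromatic nitrogen. Within the data shown here, no measured pair shows the effect of such a rearrangement, so the step of a 1.2-fold higher number from compound 2 to compound 3 (0.08 log units; within the scatter) is expected to stay within the usual scatter, with no clear direction. Compound 3 is therefore estimated at 25000 nM, most likely between 8000 nM and 80000 nM.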

Compound 3, half-maximal cytotoxic concentration: 26700 nM
Compound 3: the middle estimate sits 1.1-fold (0.03 log units) below what was measured; the range from low to high includes it.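

In this assay, 4-chlorophenyl in place of 2-chlorophenyl on this aromatic nitrogen gives a 1.3-fold higher number from compound 2 to compound 3 (0.11 log units; within the scatter). Compounds 2 and 3 therefore cannot be told apart here, so for this pair the placement of the chlorine on the phenyl ring makes no visible difference. No other measurement available here bears on this result.

Going by these compounds, it remains open whether a different kind of group on the same nitrogen, such as a phenyl ring carrying an amine or a carboxylic acid, would shift the reading. A cyclohexyl ring at this position is equally untested among the compounds shown.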